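The compounds below may be only part of what the source reports. "The series", "measured", "known", "first", "only" and "open" are said of these compounds alone.

Measured so far in a functional assay on the whole organism (strain Wistar) for inhibition, with Rattus norvegicus as the target, read by paw edema, with stated times of 30 min and 3 h, at a dose of 200 mg/kg by the oral route; a lower number here means less inhibition, a higher number more inhibition at the dose given (going by the name of the read-out):

Compound 1 `O=C(O)c1cc(-n2c(-c3ccccc3)cc3c2CCCC3)ccc1O` — in this assay compound 1 gives >= 60%, which is a limit of the assay rather than a number.

Compound 2 `COc1cccc(-c2cc3c(n2-c2ccc(O)c(C(=O)O)c2)CCCC3)c1` — in this assay compound 2 gives 20%.

Compound 3 `COC1CCc2c(cc(-c3ccccc3)n2-c2ccc(O)c(C(=O)O)c2)C1` — in this assay compound 3 gives 40%.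

Compound 3 has the higher of the two numbers in this assay; the nearest, compound 2, stands a step lower that is beyond the scatter. The third value is a limit (the limit of >= 60% in this assay, at which 1 of the 3 values shown sits). Compound 4 `CC1CCc2c(cc(-c3ccccc3)n2-c2ccc(O)c(C(=O)O)c2)C1` differs from compound 3 in one place: methyl in place of methoxy on a saturated ring carbon. For the measured compounds named here, two measured steps bear on it. The step of a number at least 40 percentage points lower from compound 1 to compound 2 (beyond the scatter) came with methoxy in place of hydrogen on an aromatic carbon, and the step of a number at least 20 percentage points lower from compound 1 to compound 3 (beyond the scatter) came with methoxy in place of hydrogen on a saturated ring carbon. Both show a methoxy lowering the reading, and compound 4 removes that methoxy while leaving a methyl behind. Part of the lost inhibition is therefore expected to return, so a step of a number 10 percentage points higher from compound 3 to compound 4 (within the scatter) upward is expected. Compound 4 is expected to give 50%, between 30% and 70%.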

Compound 4, a percentage reported as inhibition, in the whole organism at one dose (the size of the read-out at that dose, not a potency): 40%
The estimate for compound 4 lay 10 percentage points above the measured number, and the stated range covers the measured number.
By their numbers in this assay, from the lowest: compound 2; then compounds 3 and 4 (each within the scatter of the next). At a limit, above all of these: compound 1.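

In this assay, the change of methoxy to methyl on this saturated ring carbon gives no change at the digits printed from compound 3 to compound 4 (within the scatter), so the two groups cannot be told apart at this position. The earlier compounds shown here showed a lower reading only with methoxy here, whereas the new step is a number at least 20 percentage points lower from compound 1 to compound 4 (beyond the scatter), so a group without oxygen also goes with a lower reading than hydrogen on this carbon. The exact size of that step cannot be read because compound 1 stands at a limit: the limit of >= 60% in this assay, at which 1 of the 4 values shown sits.

With only methoxy and methyl shown on this carbon, it remains open whether any group placed here goes with a similar reading. A hydroxyl, an amine or a longer chain such as propyl at the same place could read differently.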